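The compounds below may be only part of what the source reports. "The series", "measured", "known", "first", "only" and "open" are said of these compounds alone.

Compound 1 `CC1=C(C(=O)OCc2ccccc2)C(c2cccs2)NC(=O)N1` and compound 2 `CC1=C(C(=O)OCc2ccccc2)C(c2ccsc2)NC(=O)N1` differ in one place: thiophen-3-yl in place of thiophen-2-yl on a saturated ring carbon. In an assay on membranes from HeLa cells for displacement of a labelled ligand from adenosine receptor A3 (Homo sapiens), read by scintillation counting, with a stated time of 180 min, tested at 1 uM (on this read-out higher numbers stand for more inhibition at the one concentration tested (going by the name of the read-out) and lower numbers for less inhibition), compound 1 gives 8% and compound 2 gives 25%, so this change gave a number 17 percentage points higher from compound 1 to compound 2 (beyond the scatter). Compound 3 `CC1=C(c2ncc(C)o2)C(c2cccs2)NC(=O)N1` is built on another core, and the difference between the two cores is not broken down here. In this assay compound 3 gives 1%. Compound 4 `CC1=C(c2ncc(C)o2)C(c2ccsc2)NC(=O)N1` has not been measured; it differs from compound 3 by the same kind of change, (thiophen-3-yl in place of thiophen-2-yl on a saturated ring carbon), where the place is described as next to the ring atom that bears a 5-methyl-1,3-oxazol-2-yl group rather than one that bears a large group. Within the data shown here, for compound 4 a step of a number 9 percentage points higher from compound 3 to compound 4 (within the scatter) is expected, because the earlier change gave a number 17 percentage points higher from compound 1 to compound 2 (beyond the scatter), though only one example stands behind it. Compound 4 is estimated at 10%, between 0% and 28%.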

Compound 4, a percentage reported as inhibition, at one concentration (the size of the read-out at that concentration, not a potency): 2%
Compound 4: the middle estimate sits 8 percentage points above what was measured; the range from low to high includes it.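

In this assay, putting thiophen-3-yl in place of thiophen-2-yl gave a number 1 percentage points higher from compound 3 to compound 4 (within the scatter), so the gain seen on the core of compound 1 did not carry over to the core of compound 3. The two steps differ: the same change on two cores in this assay, a number 17 percentage points higher (beyond the scatter) from compound 1 to compound 2 and a number 1 percentage points higher (within the scatter) from compound 3 to compound 4, 16 percentage points apart, beyond the scatter of two such steps. This shows that the step cannot simply be transferred between these two cores, but with one pair on each core it does not show why they differ or what would happen on a third core.

Still open, going by these compounds, is whether the larger step would return with a methyl ester or an amide on the core, and what a phenyl ring would give in place of either thiophene.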